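Swapping 4-chlorophenyl for 4-methylbenzyl on a bromoacrylamide

The source may report more compounds than this note shows. Statements on the series, on what has been measured and on what is new or still open speak of the compounds shown alone.

Two close analogues have been measured in a functional assay on HeLa cells (Homo sapiens) for inhibition, read by MTT assay, with a stated time of 72 h; a lower number here means a stronger inhibitor, a higher number a weaker inhibitor. Compound 1 `C=C(Br)C(=O)Nc1cccc(/C=C/C(=O)Nc2ccc(F)cc2)c1` gives 16800 nM, and compound 2 `C=C(Br)C(=O)Nc1cccc(/C=C/C(=O)Nc2ccc(Cl)cc2)c1` gives 2800 nM, the lower of the two numbers. Compound 2 is therefore the better inhibitor of this pair and the reference point for the next comparison.

Compound 3 `C=C(Br)C(=O)Nc1cccc(/C=C/C(=O)NCc2ccc(C)cc2)c1` departs from compound 2 at the amide end, with 4-methylbenzyl in place of 4-chlorophenyl on an amide-type nitrogen. Within the data shown here, only one measured step bears on this change, and it bears indirectly. That step is a 6.0-fold lower number from compound 1 to compound 2 (0.78 log units; beyond the scatter), produced by chloro in place of fluoro on an aromatic carbon. Among the measured compounds shown here, it shows that this assay responds to a small change in this group, but no measured compound carries a benzyl group. For the measured compounds named here, compound 3 loses the chloro involved in a 6.0-fold lower number from compound 1 to compound 2 (0.78 log units; beyond the scatter), so a modest move toward a higher number is expected, no larger than that step. The expected change is a 2.3-fold higher number from compound 2 to compound 3 (0.37 log units; beyond the scatter). For compound 3 the estimated value is 6500 nM, with an expected range of 1800 nM to 22000 nM.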

Compound 3, half-maximal inhibitory concentration: 1700 nM
For compound 3 the middle estimate is 3.8-fold (0.58 log units) above the measured one; measured number below the stated range.
By their numbers in this assay, from the lowest: compounds 3 and 2 (each within the scatter of the next); then compound 1.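

In this assay, the exchange on the amide-type nitrogen gives a 1.6-fold lower number from compound 2 to compound 3 (0.22 log units; within the scatter), so 4-methylbenzyl, with its 8 carbon heavy atoms, and 4-chlorophenyl cannot be told apart at this position. The earlier pair had varied only the halogen on an aromatic ring, whereas this result shows that a group without chlorine, and with a different attachment to the nitrogen, can read level with compound 2. Compound 1 remains apart, with a 9.9-fold lower number from compound 1 to compound 3 (0.99 log units; beyond the scatter), and no measurement offered here accounts for either step.

Compound 3 changes chloro to methyl and phenyl to benzyl in a single step, so the compounds shown do not separate these two changes from each other. On these data alone, how an unsubstituted benzyl or a longer chain such as phenethyl would read on this nitrogen remains open, as does the part played by the bromoacrylamide end, which all three compounds share.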